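A few compounds are considered here, and "the series" means these few. Any claim that something is new, unique, unknown or untested is made for them only; others in the source may bear on it.

Measured compounds:
compound 1 `CCCC1=C(C(=O)OCc2ccc(C(=O)O)cc2)C(c2cccc(C)c2)NC(=O)N1`, 3400 nM 
compound 2 `CCCC1=C(C(=O)OCC)C(c2cc(C)cc(C)c2)NC(=O)N1`, 9500 nM 
compound 3 `COc1ccc(COC(=O)C2=C(C(C)C)NC(=O)NC2c2cccc(C)c2)cc1`, 5800 nM 

The three measured compounds share one core and were all read in a functional assay on HEK293 cells (Homo sapiens), read by cAMP accumulation; on this read-out lower numbers stand for an effect already at smaller amounts and higher numbers for an effect only at larger amounts of compound. Compound 1 gives 3400 nM. Compound 3 gives 5800 nM, and this number lies within the usual scatter of the number of compound 1, so the two cannot be told apart. Compound 2 gives 9500 nM, a higher number than that of compound 1 by more than the scatter; of the three numbers shown, none is lower than that of compound 1.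

Compound 4 `CCCC1=C(C(=O)OCc2ccc(C(=O)NCCCN3CCCCC3)cc2)C(c2cccc(C)c2)NC(=O)N1` has not yet been measured. It differs from compound 1 in one place: (3-(piperidin-1-yl)propyl)amino in place of hydroxy on a carbonyl carbon. Among the compounds with values here, no measured pair in this set shows the effect of such a change, so the direction of the step is not known from the data. The group that enters is larger than the one that leaves and brings one hydrogen-bond acceptor with it. Because compound 1 already gives 3400 nM, the estimate for compound 4 starts from that number; compound 4 is expected to give about 2000 nM in this assay, in a range from 500 nM to 8000 nM. The step expected is a 1.7-fold lower number from compound 1 to compound 4 (0.23 log units; within the scatter), which is close to the scatter and may not be resolved.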

Compound 4, half-maximal effective concentration: 1900 nM
Compound 4: middle estimate off by 1.1-fold (0.02 log units), on the high side; the measured number falls inside the stated range.
By their numbers in this assay, from the lowest: compounds 4, 1, 3 and 2 (each within the scatter of the next, the first and the last beyond it).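

Within the data shown here, the pair of compound 1 and compound 4 is the first in this set that differs in one place, and in this assay it gives a 1.8-fold lower number from compound 1 to compound 4 (0.25 log units; within the scatter), so the two numbers cannot be told apart. This shows that, on this carbonyl carbon, carboxy can be replaced by the much larger (3-(piperidin-1-yl)propyl)carbamoyl, with its six-membered non-aromatic ring, without a difference that rises above the usual scatter of repeated measurements. Nothing at hand explains this result or says what the added ring and chain each contribute.

The compounds shown leave open whether a shorter chain such as ethyl, or a morpholine or a dimethylamine in place of the piperidine, would give a number that can be told apart from that of compound 1 in this assay. They also leave open what a simple primary amide or a methyl ester at this carbonyl carbon would give, and so whether the amine at the end of the chain matters at all for the number read here.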